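Swapping a pyridinylmethyl for an oxazolyl carbonyl

The source may hold more compounds than are shown below. What is called first, only, known or untested is meant among the compounds shown, and "the series" means these compounds.

Of the compounds shown here, three sharing one core have been measured in an assay on HEK293 cells for agonist activity at Toll-like receptor 8 (Homo sapiens), read by a luciferase reporter, with a stated time of 6 h; on this read-out higher numbers stand for an effect only at larger amounts of compound and lower numbers for an effect already at smaller amounts. Compound 1 `CCCCNc1nc(N)nc2c1CCN(C(=O)c1ccccc1)C2` gives 0.8 uM. Compound 2 `CCCCNc1nc(N)nc2c1CN(Cc1cccc(OC)c1Cl)CC2` gives 0.04 uM. Compound 3 `CCCCNc1nc(N)nc2c1CN(Cc1ccccn1)CC2` gives 0.07 uM, which sits second highest of the three; its gap to compound 2 lies within the usual scatter, while compound 1 is beyond the scatter from it, with the higher number.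

Compound 4 `CCCCNc1nc(N)nc2c1CN(C(=O)c1cocn1)CC2` has not yet been measured. It differs from compound 3 in one place: (1,3-oxazol-4-yl)carbonyl in place of (pyridin-2-yl)methyl on an amine nitrogen in a ring. Compound 1 also carries a carbonyl directly on its ring nitrogen, and of the three it shows the highest number, so the carbonyl-bearing compound 4 is expected to move in the same direction. The step from compound 3 to compound 4 is therefore estimated as a 7.1-fold higher number from compound 3 to compound 4 (0.85 log units; beyond the scatter), a rise in this assay beyond the scatter. For compound 4 the expected value in this assay is 0.5 uM, with a likely range from 0.1 uM to 3 uM.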

Compound 4, minimum effective concentration: 0.2 uM
Compound 4: middle estimate off by 2.5-fold (0.40 log units), on the high side; measured number inside the range.
By their numbers in this assay, from the lowest: compounds 2 and 3 (each within the scatter of the next); then compound 4; then compound 1.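

In this assay, among these compounds, the step of a 2.9-fold higher number from compound 3 to compound 4 (0.46 log units; beyond the scatter) is modest but real, and it gives the first direct comparison of two groups on the amine nitrogen in a ring of the shared core. It shows that this position responds to the change, yet compound 4 with its carbonyl still gives an effect at 0.2 uM in this read-out, so a carbonyl on this nitrogen is compatible with activity here. Nothing measured here explains why the number rises.

The swap changes the link to the nitrogen and the aromatic ring at once, so the compounds shown cannot say which of the two accounts for the step. A (pyridin-2-yl)carbonyl or a (1,3-oxazol-4-yl)methyl group on the same nitrogen would pull these two changes apart.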